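Triazole series: halogen swap on the distal phenyl

This account rests on a few compounds, and the source may have more. Where it says the series, first, only, none or still open, it means among the compounds named here.

Measured compounds:
compound 1 `Fc1ccc(CSc2nnc(-c3ccncc3)n2-c2ccccc2)cc1` — 12800 nM
compound 2 `Clc1ccc(CSc2nnc(-c3ccncc3)n2-c2ccccc2)cc1` — 10700 nM
compound 3 `O=C(CSc1nnc(-c2ccncc2)n1-c1ccccc1)N/N=C/c1ccc(Cl)cc1` — 5740 nM

All three were run in a functional assay on HCT-116 cells (Homo sapiens) for inhibition, read by MTT assay, with a stated time of 48 h; on this read-out higher numbers stand for weaker inhibition and lower numbers for stronger inhibition. Compound 2 `Clc1ccc(CSc2nnc(-c3ccncc3)n2-c2ccccc2)cc1` and compound 1 `Fc1ccc(CSc2nnc(-c3ccncc3)n2-c2ccccc2)cc1` differ only by fluoro in place of chloro on an aromatic carbon, and the step reads a 1.2-fold higher number from compound 2 to compound 1 (0.08 log units; within the scatter). Compound 3 `O=C(CSc1nnc(-c2ccncc2)n1-c1ccccc1)N/N=C/c1ccc(Cl)cc1` carries a different core; the difference between its core and that of compound 2 is not broken down here, and their values in this assay sit within the scatter of each other.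

Compound 4 `O=C(CSc1nnc(-c2ccncc2)n1-c1ccccc1)N/N=C/c1ccc(F)cc1` is not yet measured. It relates to compound 3 by fluoro in place of chloro on an aromatic carbon, the same change as between compound 2 and compound 1, at the same kind of place. Since that earlier step was a 1.2-fold higher number from compound 2 to compound 1 (0.08 log units; within the scatter), a step of similar size, a 1.2-fold higher number from compound 3 to compound 4 (0.07 log units; within the scatter), is expected here. Compound 4 is accordingly estimated at 6800 nM in this assay, with a likely range from 3500 nM to 13000 nM.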

Compound 4, half-maximal inhibitory concentration: 7040 nM
Estimate against measurement, compound 4: 1.0-fold (0.02 log units) below, and the stated range covers the measured number.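

In this assay, the change from 4-chlorophenyl to 4-fluorophenyl on the core of compound 3 reads a 1.2-fold higher number from compound 3 to compound 4 (0.09 log units; within the scatter). Set beside the same change on the core of compound 1, it carries over between the two cores with no difference that can be resolved: the same change on two cores in this assay, a 1.2-fold higher number (0.08 log units; within the scatter) from compound 2 to compound 1 and a 1.2-fold higher number (0.09 log units; within the scatter) from compound 3 to compound 4, 1.0-fold (0.01 log units) apart, within the scatter of two such steps

Both steps lie within the scatter, so the notes support only a halogen swap that stays unresolved on these two cores, not a real effect of the swap or a rule for the whole series. Open, from the compounds shown here alone, is how other groups at this place on the phenyl ring would behave, such as a methoxy, a nitrile or an amine. Only a step beyond the scatter on both cores would give transfer between cores a real test.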